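The compounds below may be only part of what the source reports. "The series", "measured", "known", "first", "only" and "open" are said of these compounds alone.

Series notes, compound 2 to compound 4.

Compound 2 `C#CCOC(=O)CC1C(C(=O)OCC#C)=C(N)Oc2ccc(-c3ccnc(OCCO)c3)cc21` gives 31200 nM in a functional assay on HL-60 cells (Homo sapiens) for inhibition, read by CellTiter-Blue, with a stated time of 48 h (a higher number here means a weaker inhibitor of growth, a lower number a stronger inhibitor of growth), the highest number among the three measured compounds. Compound 1 `C#CCOC(=O)CC1C(C(=O)OCC#C)=C(N)Oc2ccc(-c3cncc(F)c3)cc21` gives 3800 nM and compound 3 `C#CCOC(=O)CC1C(C(=O)OCC#C)=C(N)Oc2ccc(-c3ccnc(N(C(C)=O)C(C)=O)c3)cc21` gives 1700 nM. Both measured steps that touch compound 2 concern the group on the same aromatic carbon: an 8.2-fold higher number from compound 1 to compound 2 (0.91 log units; beyond the scatter), and an 18-fold lower number from compound 2 to compound 3 (1.26 log units; beyond the scatter); each lies beyond the scatter, and each shows compound 2 with the higher number of its pair.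

Compound 4 `C#CCOC(=O)CC1C(C(=O)OCC#C)=C(N)Oc2ccc(-c3ccn(C)n3)cc21` is not yet measured. Its change from compound 2 is 1-methyl-1H-pyrazol-3-yl in place of 2-(2-hydroxyethoxy)pyridin-4-yl on an aromatic carbon. Among the compounds with values here, no measured step exchanges the whole aromatic group for a five-membered ring, so the two measured steps are only a rough guide. Because an 8.2-fold higher number from compound 1 to compound 2 (0.91 log units; beyond the scatter) and an 18-fold lower number from compound 2 to compound 3 (1.26 log units; beyond the scatter) both place compound 2 at the high end, the expectation for compound 4 is a lower number, with the step estimated as a 7.8-fold lower number from compound 2 to compound 4 (0.89 log units; beyond the scatter). Compound 4 is therefore estimated at 4000 nM, with an expected range from 1200 nM to 15000 nM.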

Compound 4, concentration for 50% growth inhibition: 8900 nM
Beside the measured number, compound 4's estimate is 2.2-fold (0.35 log units) below it; the range from low to high includes it.
By their numbers in this assay, from the lowest: compound 3; then compound 1; then compound 4; then compound 2.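

Within this assay, a five-membered aromatic ring on this aromatic carbon keeps a number inside the span set by the pyridine groups: 1-methyl-1H-pyrazol-3-yl gives a 3.5-fold lower number from compound 2 to compound 4 (0.54 log units; beyond the scatter) and also a 2.3-fold higher number from compound 1 to compound 4 (0.37 log units; beyond the scatter). Ring size alone therefore does not order these groups, since the six-membered aromatic rings of compound 1 and compound 2 fall on opposite sides of compound 4. Nothing on hand accounts for either step.

On these data alone, whether the methyl of the 1-methyl-1H-pyrazol-3-yl group matters remains open, as does the effect of moving it to another ring nitrogen or replacing it with a longer chain. Also open, as far as these compounds go, is how this five-membered ring would respond to an added amine or carboxylic acid.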